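Isopropyl in place of pyrimidin-2-yl on a ring nitrogen

The source may hold more compounds than are shown below. What is called first, only, known or untested is meant among the compounds shown, and "the series" means these compounds.

Compound 1 `CC(=O)N1CCN(c2nc(Nc3ccc(C#N)c(C(F)(F)F)c3)nc(Oc3ccnc4ccccc34)n2)CC1`: in a functional assay on DU-145 cells (Homo sapiens) for cytotoxicity, read by sulforhodamine B assay, with a stated time of 48 h (on this read-out lower numbers stand for stronger inhibition of growth and higher numbers for weaker inhibition of growth), compound 1 gives > 100000 nM, which is a limit of the assay and not a number.
Compound 2 `N#Cc1ccc(Nc2nc(Oc3ccnc4ccccc34)nc(N3CCN(c4ncccn4)CC3)n2)cc1C(F)(F)F`: in this assay compound 2 gives > 100000 nM, again a limit rather than a number.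

Among the compounds with values here, compound 2 therefore stands only at a limit, and the one other value shown is a limit as well; both sit at the limit of > 100000 nM in this assay, at which 2 of the 2 values shown sit. Within the data shown here, the single measured step, a step that the two limits leave unreadable from compound 1 to compound 2, is left unreadable by the two limits, so nothing about its size or direction can be taken from it.

Compound 3 `CC(C)N1CCN(c2nc(Nc3ccc(C#N)c(C(F)(F)F)c3)nc(Oc3ccnc4ccccc34)n2)CC1` is the next member of the series and has not been measured in this assay. It differs from compound 2 by isopropyl in place of pyrimidin-2-yl on an amine nitrogen in a ring. Among the measured compounds shown here, no measured step bears on this change in a readable way, since the only step recorded is itself hidden behind two limits. The expectation for compound 3 is therefore a step that the limit leaves unreadable from compound 2 to compound 3 that cannot be distinguished from none beyond the scatter. Compound 3 is estimated at 150000 nM, within a range from 30000 nM to 500000 nM, most likely reported again as a limit.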

Compound 3, concentration for total growth inhibition: > 100000 nM
Compound 3: no number, only a limit; the forecaster's own chance of this, stated with the estimate: 85%; the middle value is on the limit's open side.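

No new step can be read among compound 1, compound 2 and compound 3, since each stands only at a limit of the assay and not at a number: (the limit of > 100000 nM in this assay, at which 3 of the 3 values shown sit). The compounds shown leave open whether acetyl, pyrimidin-2-yl or isopropyl on the ring nitrogen makes any difference in this assay at all.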